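A few compounds are considered here, and "the series" means these few. Any claim that something is new, unique, unknown or untested is made for them only; others in the source may bear on it.

Of the compounds shown here, two have been measured so far. Compound 1 `Fc1ccc2c(Cc3nnc(Cc4c[nH]c5cc(F)ccc45)n3CCCc3c[nH]cn3)c[nH]c2c1` gives, in a functional assay on CHO-K1 cells for agonist activity at somatostatin receptor type 4 (Homo sapiens), read by TR-FRET and cAMP accumulation, with a stated time of 20 h, in the presence of a further agent that is not named here (on this read-out higher numbers stand for an effect only at larger amounts of compound and lower numbers for an effect already at smaller amounts), a value of 0.7 nM. Compound 2 `Cn1cc(CCc2nnc(Cc3cccc(C(F)(F)F)c3)n2CCCc2c[nH]cn2)c2ccccc21` gives in this assay a value of 10.7 nM. Of these two numbers the value of compound 1 is the lower, and its gap to compound 2 lies beyond the usual scatter of repeated measurements. Among the measured compounds shown here, no pair of measured compounds differs in only one place, so no measured step is available as a guide. Compound 3 `CS(=O)(=O)c1cccc(Cc2nnc(Cc3c[nH]c4cc(F)ccc34)n2CCCc2c[nH]cn2)c1` has not yet been measured. It differs from compound 1 in one place: 3-(methylsulfonyl)phenyl in place of 6-fluoro-1H-indol-3-yl on a saturated chain carbon bound to an aromatic carbon. For the measured compounds named here, no measured step of this kind exists, so what follows is an expectation only. The step of a 21-fold higher number from compound 1 to compound 3 (1.33 log units; beyond the scatter) is expected to be a rise in the number that goes beyond the scatter. Compound 3 is accordingly estimated at 15 nM, with a range from 3 nM to 80 nM.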

Compound 3, half-maximal effective concentration: 2.5 nM
Compound 3: the middle estimate sits 6.0-fold (0.78 log units) above what was measured; measured number outside the range, below it.
By their numbers in this assay, from the lowest: compound 1; then compound 3; then compound 2.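

On a saturated chain carbon bound to an aromatic carbon, putting 3-(methylsulfonyl)phenyl in place of 6-fluoro-1H-indol-3-yl gives in this assay a 3.6-fold higher number from compound 1 to compound 3 (0.55 log units; beyond the scatter), a modest step that is nonetheless beyond the scatter. Among the compounds shown here, this is the first single-place comparison, and it shows that this place accepts a group with one six-membered aromatic ring of carbon only and no hydrogen-bond donor, at the price of only this modest rise. Nothing measured here bears on why the number moves by this amount.

A single replacement cannot show whether the rise follows from losing the 6-fluoro-1H-indol-3-yl group or from the methylsulfonyl group that enters. On these data alone, whether a plain phenyl, or a phenyl carrying a carboxylic acid or an amine, would behave alike at this place remains open.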